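Chloro in place of hydrogen on the phenyl group

The source may report more compounds than this note shows. Statements on the series, on what has been measured and on what is new or still open speak of the compounds shown alone.

Measured in a functional assay on HCT-116 cells (Homo sapiens) for inhibition, with a stated time of 48 h; on this read-out lower numbers stand for stronger inhibition of growth and higher numbers for weaker inhibition of growth:
- compound 1 `COc1c(C(=O)/C=C/c2ccc(Cl)cc2)c(O)c(Br)c2occc12`: 2830 nM
- compound 2 `C=CCc1c(O)c(C(=O)/C=C/c2ccccc2)c(OC)c2ccoc12`: 3030 nM

Compound 2, at 3030 nM, lies within the scatter of compound 1, at 2830 nM, so the two numbers do not separate these compounds. The next step leads to compound 3 `C=CCc1c(O)c(C(=O)/C=C/c2ccc(Cl)cc2)c(OC)c2ccoc12`, with chloro in place of hydrogen on an aromatic carbon, para to a large group, or phenyl to 4-chlorophenyl. Among the measured compounds shown here, no measured pair isolates this change. Compound 1 already carries 4-chlorophenyl and gives 2830 nM, but it also differs from compound 2 elsewhere, so it is only a loose guide. In this assay, the expected change is small, a 1.4-fold lower number from compound 2 to compound 3 (0.14 log units; within the scatter), toward stronger inhibition of growth and not clearly beyond the scatter. Compound 3 is estimated at 2200 nM, with an expected range of 900 nM to 5000 nM.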

Compound 3, concentration for 50% growth inhibition: 2740 nM
The estimate for compound 3 lay 1.2-fold (0.10 log units) below the measured number; the measured number falls inside the stated range.
By their numbers in this assay, from the lowest: compounds 3, 1 and 2 (each within the scatter of the next).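

In this assay the change from phenyl to 4-chlorophenyl, now seen alone, gives a 1.1-fold lower number from compound 2 to compound 3 (0.04 log units; within the scatter) and so does not separate the two compounds. With 4-chlorophenyl held fixed, allyl in place of bromo on an aromatic carbon gives a 1.0-fold lower number from compound 1 to compound 3 (0.01 log units; within the scatter) and leaves that pair unseparated as well, so neither single change shifts the read-out beyond the scatter. No supporting evidence bears on these results.

On these data alone, it remains open whether an amine or a carboxylic acid in place of chloro, para to a large group, would give a step beyond the scatter. As far as these compounds go, it is equally open whether a longer chain in place of allyl would do so on the shared core.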